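Swapping Fluoro for Sulfanyl on a Stable Core

This account rests on a few compounds, and the source may have more. Where it says the series, first, only, none or still open, it means among the compounds named here.

Compound 3 `Fc1cc(C(F)(F)F)cc(C(F)(F)F)c1` is one of three small aromatic compounds whose survival in buffer was followed in an ADME assay for pharmacokinetics, read by LC-MS, in phosphate buffer, with a stated time of 72 h, at pH 7.4, tested at 250 uM; on this read-out lower numbers stand for a shorter-lived compound and higher numbers for a longer-lived compound. In this assay compound 3 sits at a limit of the method, > 50 h. Compound 2 `N#Cc1cc(C(F)(F)F)cc(C(F)(F)F)c1` also reaches a limit, > 50 h. Compound 1 `O=C1C=CC(=O)N1c1cc(C(F)(F)F)cc(C(F)(F)F)c1` instead falls at the opposite limit, < 0.017 h. So compound 3 stands at the top of what the method can report, sharing that position with compound 2, because of the limit of > 50 h in this assay, at which 2 of the 3 values shown sit.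

The two readable steps are large: an at least 2900-fold higher number from compound 1 to compound 2 (3.46 log units; beyond the scatter) and an at least 2900-fold higher number from compound 1 to compound 3 (3.46 log units; beyond the scatter), both where the five-membered ring of compound 1 is replaced. The step between the two stable compounds cannot be sized, since a step that the two limits leave unreadable from compound 2 to compound 3.

Compound 4 `FC(F)(F)c1cc(S)cc(C(F)(F)F)c1` differs from compound 3 by sulfanyl in place of fluoro on an aromatic carbon. Going by the values given here, no measured step removes or adds a sulfanyl group, and the only step comparable in scale, from compound 2 to compound 3, is unreadable. The change is therefore expected to give little movement in this assay, with the outcome most likely again near the upper limit, so the step of an at least 1.2-fold lower number from compound 3 to compound 4 (0.09 log units; that floor lies within the scatter) is estimated as small. Compound 4 is expected to show about 40 h, within a range from 8 h to 100 h.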

Compound 4, half-life: 11.2 h
For compound 4 the middle estimate is 3.6-fold (0.55 log units) above the measured one, and the stated range covers the measured number.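

At this aromatic carbon the change is not neutral in this assay: sulfanyl in place of fluoro gives an at least 4.4-fold lower number from compound 3 to compound 4 (0.64 log units; beyond the scatter), and sulfanyl in place of cyano gives an at least 4.4-fold lower number from compound 2 to compound 4 (0.64 log units; beyond the scatter). Going by these compounds alone, compound 4 is also the only compound here whose half-life falls inside the reporting range of the method, and it remains far from the short-lived end of the series, with an at least 650-fold higher number from compound 1 to compound 4 (2.81 log units; beyond the scatter), a step that is only a floor because compound 1 sits at a limit of the method: the limit of < 0.017 h in this assay, at which 1 of the 4 values shown sits. The two lower steps are floors as well, not full sizes, because compound 2 and compound 3 sit at the other limit of the method: the limit of > 50 h in this assay, at which 2 of the 4 values shown sit.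

The step from compound 2 to compound 3 cannot be read, so nitrile and fluoro cannot be ranked against each other, and a single sulfanyl compound cannot show what in that group goes with the shorter half-life. Also open, on these data alone, is where an amine, a hydroxyl group or a methylsulfanyl group at this same carbon would fall in this buffer.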